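Oral exposure notes: compound 3 to compound 4

The source may hold more compounds than are shown below. What is called first, only, known or untested is meant among the compounds shown, and "the series" means these compounds.

In an ADME assay on the whole organism for pharmacokinetics, with Mus musculus as the target, at a dose of 10 mg/kg by the oral route (a lower number here means less compound in the circulation, a higher number more compound in the circulation at the dose given), compound 1 `CC/C(=C(/c1ccc(/C=C/C(=O)O)cc1)c1ccc2[nH]ncc2c1)c1ccccc1` gives 5800 ng.h/mL and compound 2 `CC/C(=C(/c1ccc(/C=C/C(=O)O)cc1)c1ccc2[nH]ncc2c1)c1cccc(Cl)c1` gives 11000 ng.h/mL while compound 3 `CC/C(=C(/c1ccc(/C=C/C(=O)O)cc1)c1ccc2[nH]ncc2c1)c1ccccc1C` gives 7200 ng.h/mL at the same dose. Compound 3 lies within the scatter of both other compounds, so no order among the three can be read.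

Compound 4 `CC/C(=C(/c1ccc(/C=C/C(=O)O)cc1)c1ccc2[nH]ncc2c1)c1ccc(C#N)cc1Cl` differs from compound 3 at a single place (2-chloro-4-cyanophenyl in place of 2-methylphenyl on a double-bonded chain carbon bound to a double-bonded chain carbon and a saturated chain carbon). The entering 2-chloro-4-cyanophenyl stands on a double-bonded chain carbon bound to a double-bonded chain carbon and a saturated chain carbon.

Going by the values given here, three measured steps bear on this change. Chloro in place of hydrogen on an aromatic carbon gave a 1.9-fold higher number from compound 1 to compound 2 (0.28 log units; within the scatter) and methyl in place of hydrogen on an aromatic carbon gave a 1.2-fold higher number from compound 1 to compound 3 (0.09 log units; within the scatter) while the exchange of the two substituted rings gave a 1.5-fold lower number from compound 2 to compound 3 (0.18 log units; within the scatter) at the same place. Among the compounds with values here, no measured compound carries a cyano group, so that part of the change has no direct measurement behind it.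

The expectation starts from compound 3 at 7200 ng.h/mL and no step beyond the scatter is expected in this assay on this evidence. The estimated step is a 1.0-fold lower number from compound 3 to compound 4 (0.01 log units; within the scatter) and it remains uncertain. Compound 4 is estimated at 7000 ng.h/mL with an expected range from 2800 ng.h/mL to 16000 ng.h/mL at this dose.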

Compound 4, area under the concentration-time curve: 2900 ng.h/mL
Estimate against measurement, compound 4: 2.4-fold (0.38 log units) above; the measured number falls inside the stated range.
By their numbers in this assay, from the lowest: compounds 4, 1, 3 and 2 (each within the scatter of the next, the first and the last beyond it).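

In this assay, going by these compounds alone, the entering 2-chloro-4-cyanophenyl gives the first steps beyond the scatter, with a 2.5-fold lower number from compound 3 to compound 4 (0.39 log units; beyond the scatter) and a 3.8-fold lower number from compound 2 to compound 4 (0.58 log units; beyond the scatter) as modest steps down, whereas the steps among compounds 1, 2 and 3 all stayed within it. The place on a double-bonded chain carbon bound to a double-bonded chain carbon and a saturated chain carbon therefore responds to the ring it carries, but compound 1 goes against a general reading, since a 2.0-fold lower number from compound 1 to compound 4 (0.30 log units; within the scatter) stays within the scatter. The measurements shown offer no evidence on what lies behind the lower exposure of compound 4.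

The entering ring brings chloro and nitrile together, so it remains open whether either group alone would give the same result at this place, particularly as the chloro steps shown do not point downward. On these data alone, it is also open how a ring carrying an amine or a methoxy group in place of the nitrile would stand in this assay against compound 2 and compound 3.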